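Swapping isoquinolinyl for chlorophenyl on a triazole hydroxamate

The source may hold more compounds than are shown below. What is called first, only, known or untested is meant among the compounds shown, and "the series" means these compounds.

Measured compounds:
compound 1 `COc1ccc(-n2nc(-c3ccccc3)nc2CNc2ccc(C(=O)NO)cc2)cc1` gives 63.4% in an assay on Sf9 cells for inhibition of protein deacetylase HDAC6 (Homo sapiens), read by fluorescence, with a stated time of 40 min, tested at 100 nM; on this read-out lower numbers stand for less inhibition and higher numbers for more inhibition at the one concentration tested (going by the name of the read-out)
compound 2 `O=C(NO)c1ccc(NCc2nc(-c3cccc4cnccc34)nn2-c2ccccc2)cc1` gives 40.2%
compound 3 `Cc1ccc(-n2nc(-c3ccccc3)nc2CNc2ccc(C(=O)NO)cc2)cc1` gives 60.7%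

Compound 2 stands lowest of the three; compound 3 is nearest, and compound 1 is furthest, both beyond the scatter. Compound 4 `O=C(NO)c1ccc(NCc2nc(-c3ccc(Cl)cc3)nn2-c2ccccc2)cc1` is not yet measured. It differs from compound 2 in one place: 4-chlorophenyl in place of isoquinolin-5-yl on an aromatic carbon. Within the data shown here, no measured step covers this exchange. Among the measured compounds shown here, the only step recorded, a number 2.7 percentage points lower from compound 1 to compound 3 (within the scatter), concerns a different position and lies within the scatter, so it says nothing about the change at hand. What can be said is that compounds 1 and 3, which carry a phenyl at the carbon where compound 2 carries isoquinolin-5-yl, both stand well above compound 2. Since 4-chlorophenyl is closer to phenyl than isoquinolin-5-yl is, compound 4 is expected to rise toward those numbers, with a number 14.8 percentage points higher from compound 2 to compound 4 (beyond the scatter) as the expected step. Compound 4 is therefore estimated at 55%, within 35% to 72%.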

Compound 4, a percentage reported as inhibition, at one concentration (the size of the read-out at that concentration, not a potency): 67.2%
Beside the measured number, compound 4's estimate is 12.2 percentage points below it; measured number inside the range.
By their numbers in this assay, from the lowest: compound 2; then compounds 3, 1 and 4 (each within the scatter of the next).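

Among these compounds, at this aromatic carbon of the five-membered ring with 3 nitrogen, the exchange of isoquinolin-5-yl for 4-chlorophenyl in this assay gives a number 27 percentage points higher from compound 2 to compound 4 (beyond the scatter), the first step in this set to lie beyond the scatter, so the number here responds to the group this carbon carries. The exchange alters several things at once: a two-ring group of 10 heavy atoms with a ring nitrogen and 1 hydrogen-bond acceptor leaves, and a single ring of 7 heavy atoms with a chlorine and no acceptor enters. No measurement here explains why the number moves.

From the compounds shown here alone, whether the step follows from losing the second ring and its nitrogen or from gaining the chlorine remains open. Also open, going by these compounds, is how a smaller or charged group, such as a 4-aminophenyl or a 4-carboxyphenyl, would read at this carbon.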